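A few compounds are considered here, and "the series" means these few. Any claim that something is new, unique, unknown or untested is made for them only; others in the source may bear on it.

Measured so far in a functional assay on the whole organism (Pleural cavity) for inhibition, with Rattus norvegicus as the target, at a dose of 25 mg/kg; a lower number here means less inhibition, a higher number more inhibition at the dose given (going by the name of the read-out):

compound 1, `CC1(Sc2ccccc2)C(=O)N(c2ccccc2)c2ncccc21`: 0%
compound 2, `CC1(Cc2ccccc2)C(=O)N(c2ccccc2)c2ncccc21`: 9%
compound 3, `COCCSC1(C)C(=O)N(c2ccccc2)c2ncccc21`: 26%

Compound 3 stands highest of the three numbers. Its nearest neighbour is compound 2, with the step of a number 17 percentage points higher from compound 2 to compound 3 (beyond the scatter), and its furthest is compound 1, with the step of a number 26 percentage points higher from compound 1 to compound 3 (beyond the scatter); both steps lie beyond the scatter. Compound 1 and compound 2 differ by a number 9 percentage points higher from compound 1 to compound 2 (within the scatter), which is within the scatter.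

Compound 4, `CC1C(=O)N(c2ccccc2)c2ncccc21`, has not yet been measured in this assay. The change from compound 3 is hydrogen in place of (2-methoxyethyl)sulfanyl on a saturated ring carbon.

Among the measured compounds shown here, two measured steps bear on this position. From compound 1 to compound 3 the group on the sulfur was exchanged, and from compound 2 to compound 3 the whole group on that saturated ring carbon was exchanged; each moved the read-out modestly, and each ended at compound 3. For the measured compounds named here, no measured step removes the group altogether and leaves hydrogen. The two compounds that lack the (2-methoxyethyl)sulfanyl group both sit low. A downward step is therefore expected, estimated as a number 16 percentage points lower from compound 3 to compound 4 (beyond the scatter). For compound 4 the expected value is 10%, with a range of 0% to 30%.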

Compound 4, a percentage reported as inhibition, in the whole organism at one dose (the size of the read-out at that dose, not a potency): 29%
Beside the measured number, compound 4's estimate is 19 percentage points below it; the measured number falls inside the stated range.
By their numbers in this assay, from the lowest: compounds 1 and 2 (each within the scatter of the next); then compounds 3 and 4 (each within the scatter of the next).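

Replacing (2-methoxyethyl)sulfanyl with hydrogen on the saturated ring carbon gives (a number 3 percentage points higher from compound 3 to compound 4 (within the scatter)) in this assay, so within this pair the read-out at this dose does not depend on that group. Hydrogen on the same carbon also gives (a number 20 percentage points higher from compound 2 to compound 4 (beyond the scatter)) and (a number 29 percentage points higher from compound 1 to compound 4 (beyond the scatter)), which changes how the earlier numbers read: the low values of compounds 1 and 2 go with benzyl and phenylsulfanyl being present, not with (2-methoxyethyl)sulfanyl being absent, and none of the four compounds goes against this. No measurement on hand accounts for this difference between the groups.

Still open, as far as these compounds go, is whether any group on this carbon can lift the read-out beyond the level shared by compounds 3 and 4, for instance an amine, a carboxylic acid or a short hydroxyethyl chain. Also open, from the compounds shown here alone, is whether the methyl group on the same carbon matters, and whether a plain phenyl or a longer alkyl chain there would fall with benzyl and phenylsulfanyl or with hydrogen.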